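Carbamoyl in place of cyano on compound 1

This account rests on a few compounds, and the source may have more. Where it says the series, first, only, none or still open, it means among the compounds named here.

Two compounds have been measured so far in a physicochemical assay for solubility, in phosphate buffer, with a stated time of 2 h, at pH 7.4 (on this read-out lower numbers stand for lower solubility and higher numbers for higher solubility), as follows
compound 1 `COc1ccc2oc(=O)cc(-c3cccc(C#N)c3)c2c1` reads 40000 nM in this test
compound 2 `COc1ccc2oc(=O)cc(-c3ccc(S(C)(=O)=O)nc3)c2c1` reads 120000 nM in this test

Compound 1 stands lowest of these two, and compound 2 lies above it by more than the usual scatter. As far as these compounds go, the change carbamoyl in place of cyano on an aromatic carbon puts carbamoyl in place of cyano on an aromatic carbon, meta to a large group, and leads to compound 3 `COc1ccc2oc(=O)cc(-c3cccc(C(N)=O)c3)c2c1` whose value is still unknown. Going by the values given here, no measured pair shows this change, so the expectation is tentative. A moderate rise, just beyond the scatter, is expected in this assay as the estimated 2.5-fold higher number from compound 1 to compound 3 (0.40 log units; beyond the scatter) shows. For compound 3 the estimated value is 100000 nM with an expected range from 40000 nM to 200000 nM in this test.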

Compound 3, solubility: 120000 nM
The estimate for compound 3 lay 1.2-fold (0.08 log units) below the measured number, within the range that was stated.
By their numbers in this assay, from the lowest: compound 1; then compounds 2 and 3 (each within the scatter of the next).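

In this assay, going by these compounds alone, carbamoyl in place of cyano gives a 3.0-fold higher number from compound 1 to compound 3 (0.48 log units; beyond the scatter), the first measured step at this aromatic carbon, showing that the read-out responds to a change at this position. The higher number comes with the entry of one hydrogen-bond donor, although a single pair cannot separate this from the other differences between the groups. No available evidence bears on why the number changes. The compounds shown leave open whether an amine or a carboxylic acid on the same carbon would give a similar number.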